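Rat Plasma Free Fraction on Replacing a Cyclopropyl Side Chain

The compounds below may be only part of what the source reports. "The series", "measured", "known", "first", "only" and "open" are said of these compounds alone.

- Compound 1 `CCC(C1CC1)n1c(=O)c(C)nc2c(-c3cc(Cl)c(OC(F)F)cc3C)ncnc21` gives 0.004 in an ADME assay on a cell-free system (plasma, Rattus norvegicus) for protein binding; on this read-out higher numbers stand for a larger free fraction and lower numbers for a smaller free fraction
- Compound 2 `CC[C@@H](C1CC1)n1c(=O)c(C)nc2c(-c3ccc(Cl)cc3Cl)ccnc21` gives 0.002 in this assay

Compound 2 (0.002) stands within the usual scatter of compound 1 (0.004), so this assay does not separate them. Compound 3 `CC[C@H](COC)n1c(=O)c(C)nc2c(-c3ccc(Cl)cc3Cl)ccnc21` carries 1-(methoxymethyl)propyl in place of 1-cyclopropylpropyl on an aromatic nitrogen. For the measured compounds named here, no measured pair shows this change. The expected step of a 2.5-fold higher number from compound 2 to compound 3 (0.40 log units; beyond the scatter) is a small rise in free fraction, only slightly beyond the scatter. For compound 3 an estimated 0.005 is expected, with 0.002 to 0.012 as the expected range.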

Compound 3, unbound fraction: 0.004
Compound 3: the middle estimate sits 1.3-fold (0.10 log units) above what was measured; the range from low to high includes it.
By their numbers in this assay, from the lowest: compounds 2, 1 and 3 (each within the scatter of the next).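

In this assay the swap of 1-cyclopropylpropyl for 1-(methoxymethyl)propyl on the aromatic nitrogen amounts to a 2.0-fold higher number from compound 2 to compound 3 (0.30 log units; within the scatter) and so does not separate the two compounds. The earlier compounds shown here carried only 1-cyclopropylpropyl here; compound 3 shows that this position can lose the three-membered ring and gain one hydrogen-bond acceptor without a change in unbound fraction that can be told from the scatter. Nothing given here explains this result. On these data alone, whether an amine or a carboxylic acid on this side chain would move the unbound fraction beyond the scatter remains open.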